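Swapping Fluoro for Bromo on a Weak Antiproliferative

This account rests on a few compounds, and the source may have more. Where it says the series, first, only, none or still open, it means among the compounds named here.

In a functional assay on A549 cells (Homo sapiens) for antiproliferative activity, read by sulforhodamine B assay, with a stated time of 72 h (on this read-out higher numbers stand for weaker inhibition and lower numbers for stronger inhibition), compound 2 `O=C(/C=C/c1csc2ccccc12)c1ccccc1O` gives 5300 nM and compound 3 `O=C(/C=C/c1csc2ccccc12)c1cc(F)ccc1O` gives 7100 nM and these two values lie within the scatter of each other. Compound 1 `COc1c(OC(C)C)cc2ccc(-c3cc(=O)c4ccccc4o3)cc2c1OC(C)C` gives > 10000 nM as its reading, which is a limit of the assay and not a number. Among the measured compounds shown here, compound 3 therefore has compound 2 as its only close neighbour on the numbers, and both sit in the micromolar range, where inhibition is modest.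

The next compound, compound 4 `O=C(/C=C/c1csc2ccccc12)c1cc(Br)ccc1O`, differs from compound 3 in one group: bromo in place of fluoro on an aromatic carbon means bromo in place of fluoro on an aromatic carbon, para to a hydroxy group.

For the measured compounds named here, only one measured step touches this carbon. Fluoro in place of hydrogen there gave a 1.3-fold higher number from compound 2 to compound 3 (0.13 log units; within the scatter) and so moved nothing beyond the scatter. Going by the values given here, no bromo compound has been measured yet, so this small step is the only guide, and it is a thin one. A large change in this assay is therefore not expected, and no direction can be claimed with confidence. The expected step is a 1.3-fold lower number from compound 3 to compound 4 (0.11 log units; within the scatter) on this estimate. The estimated value for compound 4 is 5500 nM with 2300 nM to 10000 nM as the expected range.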

Compound 4, half-maximal inhibitory concentration: 660 nM
The estimate for compound 4 lay 8.3-fold (0.92 log units) above the measured number; the measured number lies below the stated range.
By their numbers in this assay, from the lowest: compound 4; then compounds 2 and 3 (each within the scatter of the next). At a limit, above all of these: compound 1.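

In this assay, this carbon proved to be far from indifferent to what it carries: the earlier fluoro-for-hydrogen change stayed within the scatter (a 1.3-fold higher number from compound 2 to compound 3 (0.13 log units; within the scatter)), whereas exchanging one halogen for another produced a large move (an 11-fold lower number from compound 3 to compound 4 (1.03 log units; beyond the scatter)). Compared directly with the compound that has only hydrogen there, bromo also stands clear of the scatter (an 8.0-fold lower number from compound 2 to compound 4 (0.90 log units; beyond the scatter)), so among these three compounds the lower number goes with bromo and not with the presence of just any halogen at this position. Nothing among the measurements given here accounts for the difference between bromo and fluoro at this carbon.

Going by these compounds, whether chloro, iodo, methoxy or an amine on the same carbon would behave more like bromo or more like fluoro remains open, and so does whether bromo would have the same effect on a different carbon of this ring. These compounds also leave open whether the lower number of compound 4 would carry over to other cell lines, since all the values here come from a single kind of cell.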